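Naphthyl replaces trifluoromethylbenzyl: expected solubility of compound 4

This account rests on a few compounds, and the source may have more. Where it says the series, first, only, none or still open, it means among the compounds named here.

Measured compounds:
- compound 1 `COc1cccc(Oc2ccc3c(NCCCNCc4cc(F)ccc4OC)ccnc3c2)c1`: 14500 nM
- compound 2 `COc1ccc(-c2ccc3c(NCCCNCc4cc(F)ccc4OC)ccnc3c2)cc1`: 32000 nM
- compound 3 `COc1ccc(F)cc1CNCCCNc1ccnc2cc(Cc3cccc(C(F)(F)F)c3)ccc12`: 4200 nM

Of the compounds shown here, three sharing one core have been tested in a physicochemical assay for solubility, with a stated time of 18 h, at pH 7.4; on this read-out lower numbers stand for lower solubility and higher numbers for higher solubility. Compound 3 gives the lowest of the three numbers: the step of a 3.5-fold lower number from compound 1 to compound 3 (0.54 log units; beyond the scatter) and the step of a 7.6-fold lower number from compound 2 to compound 3 (0.88 log units; beyond the scatter) both point downward, while the step of a 2.2-fold higher number from compound 1 to compound 2 (0.34 log units; beyond the scatter) runs upward. Within this small set, a 3-(trifluoromethyl)benzyl group on the core therefore goes with the smallest solubility number.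

Compound 4 `COc1ccc(F)cc1CNCCCNc1ccnc2cc(-c3cccc4ccccc34)ccc12` differs from compound 3 in one place: naphthalen-1-yl in place of 3-(trifluoromethyl)benzyl on an aromatic carbon. Going by the values given here, no measured step involves a naphthalen-1-yl group, so nothing tested here matches this change directly. The nearest guide is that compound 3, with a group of no donors and no acceptors, sits lowest; the entering group likewise has no donors and no acceptors, with one aromatic ring more and the three fluorines gone.

For compound 4 a step of a 1.5-fold lower number from compound 3 to compound 4 (0.18 log units; within the scatter) in this assay is expected, roughly flat to slightly downward, and the estimate is 2800 nM with a range from 700 nM to 11000 nM.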

Compound 4, solubility: 32000 nM
Compound 4: middle estimate off by 11-fold (1.06 log units), on the low side; measured number outside the range, above it.
By their numbers in this assay, from the lowest: compound 3; then compound 1; then compounds 2 and 4 (each within the scatter of the next).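

On this assay, putting naphthalen-1-yl in place of 3-(trifluoromethyl)benzyl at this position moves the number clearly upward (a 7.6-fold higher number from compound 3 to compound 4 (0.88 log units; beyond the scatter)), although both groups count 0 hydrogen-bond donors and 0 hydrogen-bond acceptors, so those counts alone cannot account for the low number of compound 3. Naphthalen-1-yl also matches 4-methoxyphenyl (no change at the digits printed from compound 2 to compound 4 (within the scatter)) and gives a higher number than 3-methoxyphenoxy (a 2.2-fold higher number from compound 1 to compound 4 (0.34 log units; beyond the scatter)), which leaves compound 3 as the only low outlier among these four compounds. No measurement shown here explains these differences.

A plain benzyl group would help separate the loss of the three fluorines from the other differences in this change. From the compounds shown here alone, how an amine or a carboxylic acid at this position would compare remains open.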